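Swapping the amine ring on compound 2: expected cytotoxicity

This account rests on a few compounds, and the source may have more. Where it says the series, first, only, none or still open, it means among the compounds named here.

Measured compounds:
- compound 1 `O=C(/C=C/c1ccc(Cl)cc1)c1ccc(N2CCCCC2)cc1`: 235 ug/mL
- compound 2 `CN1CCN(c2ccc(C(=O)C3CC3c3ccc(Cl)cc3)cc2)CC1`: 82.1 ug/mL
- compound 3 `O=C(c1ccc(N2CCN(c3cccc(Cl)c3Cl)CC2)cc1)C1CC1c1ccc(Cl)cc1`: 383 ug/mL

In an ADME assay on Vero cells (Chlorocebus sabaeus) for cytotoxicity, with a stated time of 72 h (on this read-out higher numbers stand for lower toxicity in this test and lower numbers for higher toxicity in this test), compound 2 gives 82.1 ug/mL, the lowest of the three numbers shown, meaning it was the most toxic of this small set. For the measured compounds named here, compound 1 sits a 4.7-fold higher number from compound 2 to compound 3 (0.67 log units; beyond the scatter) is the only single-point change that has been measured here; it describes the move from compound 2 to compound 3, where a 2,3-dichlorophenyl replaces the methyl on the amine nitrogen of the ring, and the number rose beyond the scatter. Going by the values given here, compound 1 shares the piperidin-1-yl group of the unmeasured compound 4 but differs elsewhere, so no single step connects it to compound 2, and only the value of compound 1, 235 ug/mL, can be compared directly.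

Compound 4 `O=C(c1ccc(N2CCCCC2)cc1)C1CC1c1ccc(Cl)cc1` differs from compound 2 by piperidin-1-yl in place of 4-methylpiperazin-1-yl on an aromatic carbon. Among the compounds with values here, the one relevant step, the rise from compound 2 to compound 3, also removed the methyl-bearing piperazine and gave a higher number. The change here is smaller in what enters, so a modest rise in this assay is expected rather than a large one. The estimate for compound 4 is 200 ug/mL (range 90 ug/mL to 450 ug/mL), an expected step of a 2.4-fold higher number from compound 2 to compound 4 (0.39 log units; beyond the scatter).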

Compound 4, half-maximal cytotoxic concentration: 284 ug/mL
Compound 4: middle estimate off by 1.4-fold (0.15 log units), on the low side; measured number inside the range.
By their numbers in this assay, from the lowest: compound 2; then compounds 1, 4 and 3 (each within the scatter of the next).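

Putting piperidin-1-yl in place of 4-methylpiperazin-1-yl on this aromatic carbon gives a 3.5-fold higher number from compound 2 to compound 4 (0.54 log units; beyond the scatter) in this assay, so the number can rise here with no aryl group added at all. The earlier step, a 4.7-fold higher number from compound 2 to compound 3 (0.67 log units; beyond the scatter), kept the piperazine ring and put 2,3-dichlorophenyl on its nitrogen, yet compound 3 at 383 ug/mL and compound 4 at 284 ug/mL lie within the usual scatter of each other, which means that the large dichlorophenyl group is not needed to reach this level. Among the compounds sharing this core, two quite different replacements therefore lead away from the low value of compound 2, but nothing shown here explains why the number moves.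

On these data alone, it remains open whether the methyl or the piperazine ring itself goes with the lower number, which an unsubstituted piperazin-1-yl at the same place would help to separate, and how a morpholin-4-yl ring would read. As far as these compounds go, it is also open whether 4-methylpiperazin-1-yl would lower the number on the core of compound 1 as well.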